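The compounds below may be only part of what the source reports. "The series", "measured", "known", "first", "only" and "open" are said of these compounds alone.

Working notes on the series, read in a toxicity assay on HepG2 2.2.15 cells (Homo sapiens) for cytotoxicity, read by CellTiter-Glo; a lower number here means that less compound is tolerated, a higher number that more compound is tolerated. Compound 3 `O=C1CC(C(F)(F)F)CN1c1cnn2c1CN(C(=O)Nc1cc(F)c(F)c(F)c1)C(C1CC1)C2` gives 115000 nM. Compound 2 `O=C1CC(Oc2ncc(F)cn2)CN1c1cnn2c1CN(C(=O)Nc1cc(F)c(F)c(F)c1)C(C1CC1)C2` gives 96200 nM, and a 1.2-fold higher number from compound 2 to compound 3 (0.08 log units; within the scatter) lies within the scatter, so the two measured numbers cannot be told apart. Compound 1 `N#CC1CC(=O)N(c2cnn3c2CN(C(=O)Nc2cc(F)c(F)c(F)c2)C(C2CC2)C3)C1` gives > 200000 nM, which is a limit of the assay and not a number.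

Compound 4 `O=C1CC(c2ncc(F)cn2)CN1c1cnn2c1CN(C(=O)Nc1cc(F)c(F)c(F)c1)C(C1CC1)C2` is reached from compound 3 by one change, 5-fluoropyrimidin-2-yl in place of trifluoromethyl on a saturated ring carbon.

Two kinds of measured step bear on this change. The closest is a 1.2-fold higher number from compound 2 to compound 3 (0.08 log units; within the scatter), which exchanges trifluoromethyl and (5-fluoropyrimidin-2-yl)oxy on that ring carbon and stays within the scatter. The steps away from the nitrile are an at least 2.0-fold lower number from compound 1 to compound 2 (0.31 log units; beyond the scatter) and an at least 1.7-fold lower number from compound 1 to compound 3 (0.24 log units; that floor lies within the scatter). Only the first of these has a floor beyond the scatter, and both start from a limit, so neither gives a firm size. Within the data shown here, on this evidence, no step beyond the scatter is expected in this assay, although only three compounds support that view.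

The expected step is a 1.2-fold lower number from compound 3 to compound 4 (0.06 log units; within the scatter), which is estimated to remain within the scatter. For compound 4 the estimated value is 100000 nM, with an expected range of 45000 nM to 200000 nM.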

Compound 4, half-maximal cytotoxic concentration: 115000 nM
For compound 4 the middle estimate is 1.2-fold (0.06 log units) below the measured one, and the stated range covers the measured number.
By their numbers in this assay, from the lowest: compounds 2, 3 and 4 (each within the scatter of the next). At a limit, above all of these: compound 1.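

In this assay, the saturated ring carbon two ring bonds from the ring nitrogen accepts a six-membered aromatic ring attached directly in place of a small trifluoromethyl group, and no change at the digits printed from compound 3 to compound 4 (within the scatter) shows no separation between the two groups. Compared with the (5-fluoropyrimidin-2-yl)oxy group, a 1.2-fold higher number from compound 2 to compound 4 (0.08 log units; within the scatter) shows that removing the oxygen link also leaves the reading unresolved, so compound 2, compound 3 and compound 4 cannot be told apart, even with the three different groups on this carbon. The remaining step, an at least 1.7-fold lower number from compound 1 to compound 4 (0.24 log units; that floor lies within the scatter), starts from a limit and gives no firm size, and compound 1 remains the only compound whose reading is a limit of the assay: the limit of > 200000 nM in this assay, at which 1 of the 4 values shown sits.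

Among these compounds, whether the nitrile truly stands apart from the other three groups stays open, as its only reading is a limit. Also open, on these data alone, is what an amine or a carboxylic acid on this ring carbon would give, and whether any group here moves the number beyond the scatter of compound 2, compound 3 and compound 4.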